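Swapping a Group on an Amide-Type Nitrogen

The source may hold more compounds than are shown below. What is called first, only, known or untested is meant among the compounds shown, and "the series" means these compounds.

Compound 1 `Cc1c(C)c2c(c(C)c1OC(=O)CCC(=O)NC1CC(C)(C)N([O])C(C)(C)C1)CC[C@@](C)(CCC[C@H](C)CCC[C@H](C)CCCC(C)C)O2` gives 53000 nM in a functional assay on MT4 cells (Homo sapiens) for cytotoxicity, read by MTT assay, with a stated time of 72 h (a lower number here means a stronger inhibitor, a higher number a weaker inhibitor), and compound 2 `Cc1c(C)c2c(c(C)c1OC(=O)CCC(=O)NC1CC(C)(C)N([O])C1(C)C)CC[C@@](C)(CCC[C@H](C)CCC[C@H](C)CCCC(C)C)O2` gives 87000 nM in the same read-out, so these two values lie within the scatter of each other. Compound 3 `Cc1c(C)c2c(c(C)c1OC(=O)CCC(=O)NC1CC(C)(C)N([O])C(C)(C)C1)CCC(C)(C(=O)NC1CC(C)(C)N([O])C(C)(C)C1)O2` gives 41000 nM in this assay as a lower number than that of compound 2, and this gap lies beyond the scatter. Compound 3 differs from compound 2 in more than one place, so it offers no clean comparison for the change at hand.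

Compound 4 `Cc1c(C)c2c(c(C)c1OC(=O)CCC(=O)NCC1CC(C)(C)N([O])C1(C)C)CC[C@@](C)(CCC[C@H](C)CCC[C@H](C)CCCC(C)C)O2` has not yet been measured. Its change from compound 2 is a group of 11 heavy atoms (9 carbon, 1 nitrogen, 1 oxygen; one five-membered non-aromatic ring with 1 hetero atom) in place of a group of 10 heavy atoms (8 carbon, 1 nitrogen, 1 oxygen; one five-membered non-aromatic ring with 1 hetero atom), on an amide-type nitrogen and it sits on an amide-type nitrogen whose other neighbours are: carbonyl carbon. Both groups hold one five-membered non-aromatic ring with 1 hetero atom. For the measured compounds named here, only one measured step bears on this change, and it concerns a group at the same kind of nitrogen: a 1.6-fold higher number from compound 1 to compound 2 (0.22 log units; within the scatter) is all the data show. With that single step as the guide, no change beyond the scatter is expected in this assay here. The expected step is a 1.2-fold lower number from compound 2 to compound 4 (0.06 log units; within the scatter) and it stays within the scatter. Compound 4 is estimated at 75000 nM in this assay (expected range 38000 nM to 140000 nM).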

Compound 4, half-maximal inhibitory concentration: 92000 nM
Compound 4: middle estimate off by 1.2-fold (0.09 log units), on the low side; the range from low to high includes it.
By their numbers in this assay, from the lowest: compounds 3, 1, 2 and 4 (each within the scatter of the next, the first and the last beyond it).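

In this assay, lengthening the comparison at the amide-type nitrogen gives a second group swap within the five-membered ring series: the group of 11 heavy atoms in place of the group of 10 heavy atoms yields a 1.1-fold higher number from compound 2 to compound 4 (0.02 log units; within the scatter), and set against the six-membered ring group of compound 1, the same group yields a 1.7-fold higher number from compound 1 to compound 4 (0.24 log units; within the scatter). Together with the earlier step, this means that all three pairs among compound 1, compound 2 and compound 4 now lie within the scatter, so neither the ring size nor the difference in heavy atoms separates these compounds in this read-out. Nothing in the available data offers an explanation for this result.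

Going by these compounds, all three groups on this nitrogen hold a non-aromatic ring with 1 hetero atom, so it remains open whether a group of another kind there, such as a carboxylic acid, a primary amine or a long open carbon chain, would give a step beyond the scatter. The compounds shown also leave open whether this lack of separation extends to any read-out other than this assay.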